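Replacing the Chlorophenyl Amine Arm with Dimethoxyphenyl

This account rests on a few compounds, and the source may have more. Where it says the series, first, only, none or still open, it means among the compounds named here.

Measured compounds:
compound 1, `CCOc1ccccc1Nc1nc(SCc2ccc(C(F)(F)F)cc2)nc2ccccc12` — > 50000 nM
compound 2, `FC(F)(F)c1ccc(CSc2nc(Nc3ccc(Cl)cc3)c3ccccc3n2)cc1` — 16800 nM

In a functional assay on MGC-803 cells (Homo sapiens) for cytotoxicity, read by MTT assay, with a stated time of 72 h (on this read-out lower numbers stand for stronger inhibition and higher numbers for weaker inhibition), compound 1 reaches only a limit, > 50000 nM. Among the measured compounds shown here, compound 2 is the one compound with an actual number in this assay, giving 16800 nM. For the measured compounds named here, the single measured step is an at least 2.9-fold lower number from compound 1 to compound 2 (0.47 log units; beyond the scatter), and the size of that step is bounded only by the limit of > 50000 nM in this assay, at which 1 of the 2 values shown sits.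

Compound 3, `COc1ccc(Nc2nc(SCc3ccc(C(F)(F)F)cc3)nc3ccccc23)cc1OC`, has not been measured. It differs from compound 2 in one place: 3,4-dimethoxyphenyl in place of 4-chlorophenyl on a nitrogen on an aromatic ring. Going by the values given here, no measured step involves a 3,4-dimethoxyphenyl, so the step from compound 2 bears on it only indirectly: the alkoxy-bearing 2-ethoxyphenyl of compound 1 sat at the limit, while 4-chlorophenyl gave a number. A modest move toward weaker inhibition is therefore expected for compound 3, a 1.8-fold higher number from compound 2 to compound 3 (0.25 log units; within the scatter), with a fair chance that only a limit is reported. The estimate for compound 3 in this assay is 30000 nM, within 12000 nM to 80000 nM.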

Compound 3, half-maximal inhibitory concentration: 16300 nM
For compound 3 the middle estimate is 1.8-fold (0.26 log units) above the measured one; the measured number falls inside the stated range.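

In this assay the change on this nitrogen gives a 1.0-fold lower number from compound 2 to compound 3 (0.01 log units; within the scatter) and so leaves 3,4-dimethoxyphenyl and 4-chlorophenyl indistinguishable here. Methoxy groups on this phenyl ring thus do not put a compound at the limit of the assay, a reading that the 2-ethoxyphenyl of compound 1 had left possible, and the change from that group gives an at least 3.0-fold lower number from compound 1 to compound 3 (0.48 log units; beyond the scatter) in the same direction as the step to the chlorinated compound. From the compounds shown here alone, compound 1 gives only a limit, so the true size of this step stays unknown: the limit of > 50000 nM in this assay, at which 1 of the 3 values shown sits.

The compounds shown cannot tell whether the weak result of compound 1 belongs to the ethoxy group itself or to where it sits on the ring. Going by these compounds, how a phenyl ring carrying a single methoxy, an amine or a carboxylic acid would behave on this nitrogen also remains open.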